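Swapping the ether link for a direct benzyl in compound 3

A few compounds are considered here, and "the series" means these few. Any claim that something is new, unique, unknown or untested is made for them only; others in the source may bear on it.

Of the compounds shown here, two have been measured in an assay on HEK-293T cells for inhibition of diacylglycerol lipase-alpha (Homo sapiens), read by colorimetric assay; a higher number here means a weaker inhibitor, a lower number a stronger inhibitor. Compound 1 `COc1cccc(CC2CCCCN2C(=O)n2ncc(C(O)(c3ccc(F)cc3)c3ccc(F)cc3)n2)c1` gives 3.16 nM, and compound 2 `O=C(N1CCCCC1COc1ccccc1)n1ncc(C(O)(c2ccc(F)cc2)c2ccc(F)cc2)n1` gives 5.01 nM. Among the measured compounds shown here, these are the only numbers at hand, and compound 2 stands right beside compound 1 on them: the single measured step, a 1.6-fold higher number from compound 1 to compound 2 (0.20 log units; within the scatter), changes a 3-methoxyphenyl into a phenoxy on a saturated chain carbon bound to a saturated ring carbon without moving the result beyond the scatter.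

Compound 3 `O=C(N1CCCCC1Cc1ccccc1)n1ncc(C(O)(c2ccc(F)cc2)c2ccc(F)cc2)n1` continues at the same place. The change is phenyl in place of phenoxy on a saturated chain carbon bound to a saturated ring carbon; cut one bond further out, the same difference reads phenoxymethyl to benzyl, so the oxygen linker drops away and the ring sits directly on the chain carbon. For the measured compounds named here, the only step that bears on this position is the one from compound 1 to compound 2, and it was small. With nothing pointing toward a change beyond the scatter, compound 3 is expected to land near its neighbours, with a 1.1-fold lower number from compound 2 to compound 3 (0.05 log units; within the scatter). The estimate for compound 3 is therefore 4.5 nM, within a range from 1.5 nM to 14 nM.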

Compound 3, half-maximal inhibitory concentration: 1 nM
For compound 3 the middle estimate is 4.5-fold (0.65 log units) above the measured one; the measured number lies below the stated range.
By their numbers in this assay, from the lowest: compound 3; then compounds 1 and 2 (each within the scatter of the next).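

In this assay, among the compounds shown here, this position turns out to respond to a very small edit: a 5.0-fold lower number from compound 2 to compound 3 (0.70 log units; beyond the scatter), a change that removes only the oxygen and turns phenoxymethyl into benzyl, lies beyond the scatter, whereas the one earlier step here did not. Putting hydrogen in place of methoxy on an aromatic carbon gives a second step beyond the scatter, a 3.2-fold lower number from compound 1 to compound 3 (0.50 log units; beyond the scatter), so the plain benzyl group gives the strongest inhibitor of the three, and among these compounds neither the chain oxygen nor the methoxy brings any gain. Nothing available gives a reason for either step.

The compounds shown leave open whether another group on that aromatic ring, such as chloro or an amine, would keep the number this low or bring it lower still. They also leave open how a longer chain, such as phenethyl in place of benzyl, would compare with the benzyl group on this saturated ring carbon.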